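Swapping the distal aryl for an acrylamide chain

The source may report more compounds than this note shows. Statements on the series, on what has been measured and on what is new or still open speak of the compounds shown alone.

Compound 1 `COC(=O)/C=C/c1cccc(N(Cc2ccc(-c3cccc(Cl)c3)cc2)C(=O)C2CCCCC2)c1` sits second highest of the three numbers recorded in an assay on isolated protein with Bile acid receptor (Homo sapiens) as the target (on this read-out lower numbers stand for an effect already at smaller amounts and higher numbers for an effect only at larger amounts of compound), where compound 1 gives 94 nM. Its nearest neighbour is compound 2 `COC(=O)/C=C/c1cccc(N(Cc2ccc(-c3cccc(Cl)c3)cc2)C(=O)C(C)C)c1`, which gives 77 nM; the change a 1.2-fold lower number from compound 1 to compound 2 (0.09 log units; within the scatter). Furthest away is compound 3 `COC(=O)/C=C/c1cccc(N(Cc2ccc(-c3ccc(C)cc3)cc2)C(=O)NC(C)C)c1`, which gives 449 nM; compound 3 differs from compound 1 in more than one place, so its value only shows that a combined change to the outer ring and to the carbonyl substituent can move the number well beyond the scatter.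

Compound 4 `COC(=O)/C=C/c1cccc(N(Cc2ccc(/C=C/C(=O)N(C)C)cc2)C(=O)C2CCCCC2)c1` is not yet measured. It differs from compound 1 as follows: 2-(dimethylcarbamoyl)ethenyl in place of 3-chlorophenyl on an aromatic carbon. Within the data shown here, no measured step touches this position, and the single step that exists, at the carbonyl carbon, stays within the scatter, so it offers no direct guidance. Given that compound 3 gives 449 nM after an outer-ring change, the author expects a weakening step, a 4.3-fold higher number from compound 1 to compound 4 (0.63 log units; beyond the scatter), and estimates compound 4 at 400 nM, within a range from 100 nM to 1600 nM.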

Compound 4, half-maximal effective concentration: > 1000 nM
Compound 4 was reported as a limit; the forecaster's own chance of this, stated with the estimate: 10%; middle value at least 2.5-fold (0.39 log units) away from the limit.
By their numbers in this assay, from the lowest: compounds 2 and 1 (each within the scatter of the next); then compound 3. At a limit, above all of these: compound 4.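

The first change measured at this position, on an aromatic carbon para to a large group, turns out to be large: in this assay, 2-(dimethylcarbamoyl)ethenyl in place of 3-chlorophenyl gives an at least 10-fold higher number from compound 1 to compound 4 (1.02 log units; beyond the scatter). Among these compounds, the only earlier step, at the carbonyl carbon, stayed within the scatter, whereas this one lies beyond it, even though the two groups match in heavy-atom count and differ in kind, with a chlorine-bearing aromatic ring leaving and a ringless chain entering. For compound 4 the value is a limit of the assay and not a number: the limit of > 1000 nM in this assay, at which 1 of the 4 values shown sits.

This single step cannot separate the loss of the ring from the entry of the chain; an unsubstituted phenyl, a pyridine ring or a carboxylic acid at the end of the ethenyl chain could begin to do so. From the compounds shown here alone, whether the same swap behaves alike with isopropyl on the carbonyl carbon, as in compound 2, also stays open.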